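Moving the nitro group within a chalcone series

The source may hold more compounds than are shown below. What is called first, only, known or untested is meant among the compounds shown, and "the series" means these compounds.

The shared core of compound 3 `COc1ccc(C(=O)/C=C/c2ccc([N+](=O)[O-])cc2)c2c1C=CC(C)(C)O2` carries a 4-nitrophenyl group, and in a functional assay on HT-29 cells (Homo sapiens) for antiproliferative activity, read by MTT assay, with a stated time of 24 h (on this read-out higher numbers stand for weaker inhibition and lower numbers for stronger inhibition), compound 3 gives 3730 nM. Its nearest neighbour is compound 2 `COc1ccc(C(=O)/C=C/c2ccc(N(C)C)cc2)c2c1C=CC(C)(C)O2`, which in this assay gives 1870 nM; the change is a 2.0-fold higher number from compound 2 to compound 3 (0.30 log units; within the scatter). Compound 1 `COc1cccc(/C=C/C(=O)c2ccc(OC)c3c2OC(C)(C)C=C3)c1` reaches only a limit in this assay, > 10000 nM, so that the limit of > 10000 nM in this assay, at which 1 of the 3 values shown sits, caps what can be said of it. Against it, the steps were an at least 5.3-fold lower number from compound 1 to compound 2 (0.72 log units; beyond the scatter) and an at least 2.6-fold lower number from compound 1 to compound 3 (0.42 log units; beyond the scatter). Compound 4 `COc1ccc(C(=O)/C=C/c2cccc([N+](=O)[O-])c2)c2c1C=CC(C)(C)O2` differs from compound 3 by 3-nitrophenyl in place of 4-nitrophenyl on a double-bonded chain carbon bound to a double-bonded chain carbon. Going by the values given here, no measured step moves a nitro group from one ring position to another, so the guide is only that the two measured aryl variants sit close together. Compound 4 is therefore expected to show a 1.0-fold lower number from compound 3 to compound 4 (0.00 log units; within the scatter), with an estimated value of 3700 nM in a range from 1500 nM to 9000 nM.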

Compound 4, half-maximal inhibitory concentration: 4260 nM
For compound 4 the middle estimate is 1.2-fold (0.06 log units) below the measured one, and the stated range covers the measured number.
By their numbers in this assay, from the lowest: compounds 2, 3 and 4 (each within the scatter of the next, the first and the last beyond it). At a limit, above all of these: compound 1.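

Here the nitro group's ring position is tested directly: in this assay, 3-nitrophenyl in place of 4-nitrophenyl gives a 1.1-fold higher number from compound 3 to compound 4 (0.06 log units; within the scatter), so this change does not resolve the two isomers. Compound 3 stayed within the scatter of compound 2, yet the 3-nitrophenyl variant gives a 2.3-fold higher number from compound 2 to compound 4 (0.36 log units; beyond the scatter), a small gap that rests on values close together. The remaining step, an at least 2.3-fold lower number from compound 1 to compound 4 (0.37 log units; beyond the scatter), is only a bound: the limit of > 10000 nM in this assay, at which 1 of the 4 values shown sits.

As far as these compounds go, what an amine or a carboxylic acid in place of the nitro group would give stays open. So does whether any group at this place would reach below the value of compound 2.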